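Compound 2 to compound 3: acetyl to cyclopropylsulfonyl

The source may report more compounds than this note shows. Statements on the series, on what has been measured and on what is new or still open speak of the compounds shown alone.

Measured so far in (a functional assay on HCC827 cells (Homo sapiens) for antiproliferative activity, read by MTT assay, with a stated time of 72 h; a lower number here means a stronger inhibitor, a higher number a weaker inhibitor):
- compound 1 (`CN1CCN(c2ccc(Nc3ncc4nc(Nc5ccccc5)n([C@@H]5CCN(S(=O)(=O)C6CC6)C5)c4n3)cc2)CC1`): (0.88 nM)
- compound 2 (`CC(=O)N1CC[C@H](n2c(Nc3ccccc3)nc3cnc(Nc4ccc(N5CCN(C)CC5)cc4)nc32)C1`): (260 nM)

Among the compounds with values here, of the two numbers so far, compound 2 holds the higher (260 nM). Next is compound 3 (`CN1CCN(c2ccc(Nc3ncc4nc(Nc5ccccc5)n([C@H]5CCN(S(=O)(=O)C6CC6)C5)c4n3)cc2)CC1`), which carries cyclopropylsulfonyl in place of acetyl on an amine nitrogen in a ring. Within the data shown here, one measured step bears on this, the same exchange of groups run the other way and large (a 300-fold higher number from compound 1 to compound 2 (2.47 log units; beyond the scatter)). Compound 3 is not compound 1, however, and one step is thin evidence, so only part of that size should be assumed to carry over. In (this assay) the move is expected to be large and toward a lower number and is estimated to stop short of the full size (a 17-fold lower number from compound 2 to compound 3 (1.24 log units; beyond the scatter)). For compound 3 the expected value is an estimated (15 nM), with a range from (1.5 nM) to (120 nM).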

Compound 3, half-maximal inhibitory concentration: 1.6 nM
Beside the measured number, compound 3's estimate is 9.4-fold (0.97 log units) above it, within the range that was stated.
By their numbers in this assay, from the lowest: compounds 1 and 3 (each within the scatter of the next); then compound 2.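

In this assay, the exchange of acetyl for cyclopropylsulfonyl on the amine nitrogen in the ring now reads large a second time, with a 160-fold lower number from compound 2 to compound 3 (2.21 log units; beyond the scatter), so the size of the earlier step does not rest on compound 1 alone. With cyclopropylsulfonyl in place, the drawn configuration at the saturated ring carbon makes no difference that can be read, with a 1.8-fold higher number from compound 1 to compound 3 (0.26 log units; within the scatter). The comparison isolates that one stereocentre, because nothing else separates the pair: the fact that compounds 1 and 3 differ only in the configuration as drawn.

Within the data shown here, both large steps share compound 2 as their only acetyl compound, so it remains open whether configuration matters with acetyl on the ring nitrogen. As far as these compounds go, it also remains open whether the size of the step depends on the cyclopropyl part, as a methylsulfonyl group or a plain amine hydrogen at the same nitrogen would show.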